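Methoxy Step on Two Glycosylated Cores, Vero Cytotoxicity

The source may report more compounds than this note shows. Statements on the series, on what has been measured and on what is new or still open speak of the compounds shown alone.

Measured so far:
compound 1 `CC(=O)C[C@H]1O[C@@H](On2cc(CN3C(=O)/C(=N\Nc4ccccc4)c4ccccc43)nn2)[C@H](OC(C)=O)[C@@H](OC(C)=O)[C@H]1OC(C)=O` gives 65200 nM
compound 2 `COc1ccc(N/N=C2\C(=O)N(Cc3cn(O[C@@H]4O[C@H](CC(C)=O)[C@H](OC(C)=O)[C@H](OC(C)=O)[C@H]4OC(C)=O)nn3)c3ccccc32)cc1` gives 62500 nM
compound 3 `O=C1/C(=N\Nc2ccccc2)c2ccccc2N1Cc1cn(O[C@@H]2O[C@H](CO)[C@@H](O)[C@H](O)[C@H]2O)nn1` gives 88500 nM

All three numbers come from an ADME assay on Vero cells (Chlorocebus sabaeus) for cytotoxicity, read by fluorescence and resazurin assay, with a stated time of 3 days; on this read-out lower numbers stand for higher toxicity in this test and higher numbers for lower toxicity in this test. Compound 1 and compound 2 differ by methoxy in place of hydrogen on an aromatic carbon; the step is a 1.0-fold lower number from compound 1 to compound 2 (0.02 log units; within the scatter). Compound 3 carries a different core; the difference between the core of compound 1 and the core of compound 3 is not broken down here. Compound 3 and compound 1 stand within the scatter of each other, as do compound 3 and compound 2.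

Compound 4 `COc1ccc(N/N=C2\C(=O)N(Cc3cn(O[C@@H]4O[C@H](CO)[C@@H](O)[C@H](O)[C@H]4O)nn3)c3ccccc32)cc1`, not yet measured, differs from compound 3 by methoxy in place of hydrogen on an aromatic carbon. This is the same change as between compound 1 and compound 2, with the same surroundings of the place. The expectation for this assay rests on the pair compound 1 to compound 2, where the step of a 1.0-fold lower number from compound 1 to compound 2 (0.02 log units; within the scatter) stayed within the scatter; the step from compound 3 to compound 4 is therefore expected to be small, a 1.0-fold lower number from compound 3 to compound 4 (0.02 log units; within the scatter). Compound 4 is expected at about 85000 nM, with a range from 50000 nM to 140000 nM.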

Compound 4, half-maximal cytotoxic concentration: 79600 nM
Compound 4: middle estimate off by 1.1-fold (0.03 log units), on the high side; the measured number falls inside the stated range.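

In this assay the methoxy step on the core of compound 3 is small (a 1.1-fold lower number from compound 3 to compound 4 (0.05 log units; within the scatter)) and cannot be told apart from the step on the core of compound 1: the same change on two cores in this assay, a 1.0-fold lower number (0.02 log units; within the scatter) from compound 1 to compound 2 and a 1.1-fold lower number (0.05 log units; within the scatter) from compound 3 to compound 4, 1.1-fold (0.03 log units) apart, within the scatter of two such steps

Across these two cores, then, phenyl to 4-methoxyphenyl carries over with no difference that stands out from the scatter. The finding rests on two pairs and one read-out, and since neither step stands out from the scatter, the agreement is between two steps too small to read, so it does not show how a larger step would carry from one core to another or that other cores would behave alike.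

The compounds shown leave open what an amine or a carboxylic acid would do in place of methoxy on that aromatic carbon, and whether a longer chain such as butoxy would stay as quiet there. They also leave open whether methoxy gives so small a step on any other carbon of that ring.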